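Flipping One Stereocentre on a Carbamate

The compounds below may be only part of what the source reports. "The series", "measured", "known", "first", "only" and "open" are said of these compounds alone.

Compound 1 `C=C1C(=O)OC[C@H]1CCOC(=O)Nc1c(C)cccc1C(C)C` gives 1940 nM
Compound 2 `C=C1C(=O)OC[C@@H]1CCOC(=O)Nc1ccc(Cl)cc1` gives 1070 nM

In a functional assay on RAW264.7 cells (Mus musculus) for inhibition, with a stated time of 30 min (a lower number here means a stronger inhibitor, a higher number a weaker inhibitor), compound 1 gives 1940 nM and lies within the scatter of compound 2 at 1070 nM so neither stands apart. Compared with compound 1, compound 3 `C=C1C(=O)OC[C@@H]1CCOC(=O)Nc1c(C)cccc1C(C)C` shows a single change: the two compounds have the same atoms and bonds and differ only in configuration as drawn: 1 of 1 stereo elements differ; a stereocentre at a saturated ring carbon is drawn S in compound 1 and R in compound 3 and no other. Among the compounds with values here, no measured pair shows what such a swap does to the number, so only a modest move is expected, the estimated 1.3-fold lower number from compound 1 to compound 3 (0.11 log units; within the scatter) towards a slightly lower number, possibly within the scatter. Compound 3 is expected at 1500 nM and is estimated to fall between 500 nM and 4500 nM.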

Compound 3, half-maximal inhibitory concentration: 5980 nM
Beside the measured number, compound 3's estimate is 4.0-fold (0.60 log units) below it; the whole stated range lies below it.
By their numbers in this assay, from the lowest: compounds 2 and 1 (each within the scatter of the next); then compound 3.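

In this assay, changing the stereocentre at the saturated ring carbon from S to R gives a 3.1-fold higher number from compound 1 to compound 3 (0.49 log units; beyond the scatter), so this centre matters, and the S form is the stronger inhibitor of this pair. Compounds 1 and 2 could not show this, as they differ in more than one place. The step can be assigned to this centre alone for one reason: the fact that compounds 1 and 3 differ only in the configuration as drawn

On these data alone, whether the S form stays ahead with other groups remains open. A carboxylic acid on the aromatic ring, or an amide in place of the carbamate, might behave differently.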